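Hydroxamate sulfonamide series: fluoroethoxy in place of methoxy

The compounds below may be only part of what the source reports. "The series", "measured", "known", "first", "only" and "open" are said of these compounds alone.

Measured so far in an assay on isolated protein for inhibition of matrix metalloproteinase-9 (Homo sapiens), read by fluorescence, with a stated time of 30 min; a lower number here means a stronger inhibitor, a higher number a weaker inhibitor:
- compound 1 `COc1ccc(S(=O)(=O)N(CCn2cc(CCCCOc3cccnc3F)nn2)[C@@H](C(=O)NO)C(C)C)cc1`: 0.3 nM
- compound 2 `COc1ccc(S(=O)(=O)N(CCn2cc(CN(C)S(=O)(=O)c3ccc(F)cc3)nn2)[C@@H](C(=O)NO)C(C)C)cc1`: 3 nM

Compound 2 gives the highest of the two numbers in this assay; its nearest neighbour is compound 1, and the gap between them is a 10-fold higher number from compound 1 to compound 2 (1.00 log units; beyond the scatter), a step beyond the scatter. Within the data shown here, that step sits on the saturated chain carbon bound to an aromatic carbon, on the side of the triazole, and is the only measured step in the set.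

Compound 3 `CC(C)[C@H](C(=O)NO)N(CCn1cc(CN(C)S(=O)(=O)c2ccc(F)cc2)nn1)S(=O)(=O)c1ccc(OCCF)cc1` differs from compound 2 in another place: fluoromethyl in place of hydrogen on a saturated chain carbon bound to an oxygen on an aromatic ring. The shared core, the hydroxamate and the triazole side chain of compound 2 are kept unchanged. Among the measured compounds shown here, no measured step touches the ether on the aromatic ring, so the single measured step does not bear on this change; it only shows that the series tolerates alterations at a remote position with a modest shift. With nothing measured at the ether position, a step in this assay of none beyond the scatter is expected from compound 2 to compound 3, in either direction.

For compound 3 the expected value in this assay is therefore 3 nM, with a range from 1 nM to 10 nM. The expected step of no change at the digits printed from compound 2 to compound 3 (within the scatter) is an estimate resting on the unchanged core alone.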

Compound 3, half-maximal inhibitory concentration: 11 nM
The estimate for compound 3 lay 3.7-fold (0.56 log units) below the measured number; measured number above the stated range.
By their numbers in this assay, from the lowest: compound 1; then compound 2; then compound 3.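

In this assay, among these compounds, 4-methoxyphenyl to 4-(2-fluoroethoxy)phenyl gives a 3.7-fold higher number from compound 2 to compound 3 (0.56 log units; beyond the scatter), the first reading at the ether on the aromatic ring and a step beyond the scatter. The change adds only a fluoromethyl, yet with the shared core, the hydroxamate and the triazole side chain of compound 2 held fixed, the number still moves, so this position cannot be treated as indifferent to alteration. No measured evidence bears on the origin of this shift.

The compounds shown do not separate the added chain length from the fluorine, and an ethoxy group on the same aromatic ring, set against both methoxy and 2-fluoroethoxy, would address that question directly. As far as these compounds go, it also remains open whether the same step holds with the side chain of compound 1, as the 2-fluoroethoxy group appears here only with the side chain of compound 2.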